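A few compounds are considered here, and "the series" means these few. Any claim that something is new, unique, unknown or untested is made for them only; others in the source may bear on it.

Measured so far in a functional assay on HepG2 cells (Homo sapiens) for inhibition, read by MTT assay, with a stated time of 72 h; on this read-out higher numbers stand for weaker inhibition and lower numbers for stronger inhibition:
- compound 1 `CC(C)c1ccc(NC(=O)C2CCN(C/C=C/c3ccccc3)CC2)cc1` at 12200 nM
- compound 2 `CCCCc1ccc(NC(=O)C2CCN(C/C=C/c3ccccc3)CC2)cc1` at 4320 nM
- compound 3 `O=C(Nc1cccc(C(F)(F)F)c1)C1CCN(C/C=C/c2ccccc2)CC1` at 11400 nM

Compound 1 and compound 3 share the high end of these three numbers, within the scatter of each other, while compound 2 lies clearly lower. Compound 4 `O=C(Nc1ccc(F)c(Br)c1)C1CCN(C/C=C/c2ccccc2)CC1` has not yet been measured. It differs from compound 1 as follows: 3-bromo-4-fluorophenyl in place of 4-isopropylphenyl on an amide-type nitrogen, which is 3-bromo-4-fluorophenyl in place of 4-isopropylphenyl on an amide-type nitrogen.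

Within the data shown here, only one measured step touches this aromatic group: a 2.8-fold lower number from compound 1 to compound 2 (0.45 log units; beyond the scatter), a modest change for butyl in place of isopropyl. Compound 3 also carries a different group on that nitrogen, and its value of 11400 nM sits within the scatter of compound 1. A small change is therefore expected, leaning slightly towards a lower number. The estimated step is a 1.4-fold lower number from compound 1 to compound 4 (0.13 log units; within the scatter), probably within the scatter. For compound 4 the expected value is 9000 nM, with an estimated range from 4000 nM to 20000 nM.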

Compound 4, half-maximal inhibitory concentration: 8190 nM
Compound 4: middle estimate off by 1.1-fold (0.04 log units), on the high side; low and high end bracket the measured number.
By their numbers in this assay, from the lowest: compounds 2, 4, 3 and 1 (each within the scatter of the next, the first and the last beyond it).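

In this assay the step of a 1.5-fold lower number from compound 1 to compound 4 (0.17 log units; within the scatter) stays within the scatter, so on the amide-type nitrogen a 3-bromo-4-fluorophenyl group can stand in place of 4-isopropylphenyl without a clear change in the number. The earlier compounds had shown this position only with alkyl groups and a trifluoromethyl group, and this result adds a phenyl group carrying two different halogens. Among these compounds, the only step from compound 1 that goes beyond the scatter is still a 2.8-fold lower number from compound 1 to compound 2 (0.45 log units; beyond the scatter), and no evidence is available here to explain either step.

The compounds shown leave open whether bromine alone or fluorine alone on the phenyl group would give a similar number. They also leave open whether an amine, a carboxylic acid or a chain longer than butyl would move the number further.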